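A few compounds are considered here, and "the series" means these few. Any claim that something is new, unique, unknown or untested is made for them only; others in the source may bear on it.

Of the compounds shown here, three built on a shared core have been tested so far in a functional assay on WHCO1 cells (Homo sapiens) for cytotoxicity, read by MTT assay, with a stated time of 24 h (a lower number here means a stronger inhibitor, a higher number a weaker inhibitor), and they do not score alike. Compound 1 `CC(C)=CC(O)C1=CC(=O)c2ccccc2C1=O` gives 5200 nM and compound 3 `Cc1cc(Cl)ccc1C(O)C1=CC(=O)c2ccccc2C1=O` gives 3400 nM and these two values lie within the usual scatter of each other. Compound 2 `O=C(C1=CC(=O)c2ccccc2C1=O)c1ccccc1` gives 63400 nM as the highest of the three numbers, which makes it the weakest inhibitor of the set, with both gaps beyond the scatter. Compound 4 `O=C(C1=CC(=O)c2ccccc2C1=O)c1cccc(F)c1` has not yet been measured. It departs from compound 2 by one change fluoro in place of hydrogen on an aromatic carbon that turns phenyl into 3-fluorophenyl. Within the data shown here, no two measured compounds differ in only one place, so the data offer no direct precedent. The expectation rests on compound 2 at 63400 nM and on the small size of the change, and no step beyond the scatter is expected in this assay here. The expected 1.3-fold lower number from compound 2 to compound 4 (0.10 log units; within the scatter) is therefore small. For compound 4 the estimated value is 50000 nM with an expected range from 20000 nM to 110000 nM overall.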

Compound 4, half-maximal inhibitory concentration: 94800 nM
Compound 4: the middle estimate sits 1.9-fold (0.28 log units) below what was measured; low and high end bracket the measured number.
By their numbers in this assay, from the lowest: compounds 3 and 1 (each within the scatter of the next); then compounds 2 and 4 (each within the scatter of the next).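

In this assay, the set now holds its first pair of compounds that differ in one place, and it gives a 1.5-fold higher number from compound 2 to compound 4 (0.17 log units; within the scatter). Among these compounds, this is the first direct reading at this position: fluoro in place of hydrogen on an aromatic carbon, meta to a large group, turns phenyl into 3-fluorophenyl without a step beyond the scatter, so this one change does not restore activity in this assay. No measured evidence is available to explain this outcome.

A single fluoro leaves open how a methoxy group, an amine or a carboxylic acid would read at the same place on the ring. Going by these compounds, it also remains open whether fluoro on an aromatic carbon would read the same on the aromatic ring of compound 3.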